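Sulfonamide amines: a methyl removed, a chlorine added

This account rests on a few compounds, and the source may have more. Where it says the series, first, only, none or still open, it means among the compounds named here.

Compound 1 `CC(C)(C)c1ccc(CNCCCNS(=O)(=O)c2cc(C(F)(F)F)cc(C(F)(F)F)c2)cc1`: 2500 nM
Compound 2 `CN(CCCNS(=O)(=O)c1cc(C(F)(F)F)cc(C(F)(F)F)c1)Cc1ccccc1`: > 50000 nM

Two bis(trifluoromethyl)benzenesulfonamides carrying a three-carbon chain to a benzylic amine were tested in a functional assay on PANC-1 cells (Homo sapiens) for inhibition, read by MTT assay, with a stated time of 72 h; a higher number here means a weaker inhibitor of growth, a lower number a stronger inhibitor of growth. Compound 1 `CC(C)(C)c1ccc(CNCCCNS(=O)(=O)c2cc(C(F)(F)F)cc(C(F)(F)F)c2)cc1` gives 2500 nM in this assay. For compound 2 `CN(CCCNS(=O)(=O)c1cc(C(F)(F)F)cc(C(F)(F)F)c1)Cc1ccccc1` only a limit is reported, > 50000 nM, so it stands at the limit of the assay with no number of its own; the evidence is the limit of > 50000 nM in this assay, at which 1 of the 2 values shown sits, which marks compound 2 as the weaker of the two within what the measurement can tell.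

The unmeasured compound 3 `O=S(=O)(NCCCNCc1ccc(Cl)cc1)c1cc(C(F)(F)F)cc(C(F)(F)F)c1` differs from compound 2 in one place: (4-chlorobenzyl)amino in place of benzyl(methyl)amino on a saturated chain carbon, three bonds along the chain from a sulfonamide nitrogen. With this change compound 3 comes to resemble compound 1, which bears a benzylamino group of the same kind and gives 2500 nM in this assay. Compound 3 is therefore expected to move away from the limit, with the step of an at least 12-fold lower number from compound 2 to compound 3 (1.09 log units; beyond the scatter) estimated as a clear gain beyond the scatter. The estimate for compound 3 in this assay is 4000 nM, with a range of 1200 nM to 15000 nM.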

Compound 3, concentration for 50% growth inhibition: 4900 nM
For compound 3 the middle estimate is 1.2-fold (0.09 log units) below the measured one; the range from low to high includes it.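

In this assay, among the compounds shown here, (4-chlorobenzyl)amino in place of benzyl(methyl)amino on a saturated chain carbon, three bonds along the chain from a sulfonamide nitrogen, gives an at least 10-fold lower number from compound 2 to compound 3 (1.00 log units; beyond the scatter), which shows that growth inhibition at this position can be regained with a second benzylamino group of this kind, not only with the one in compound 1. Compound 2 remains a limit and not a number, so this step fixes only a bound on the size of the change and not the size itself: the limit of > 50000 nM in this assay, at which 1 of the 3 values shown sits. Chloro in place of tert-butyl on an aromatic carbon gives a 2.0-fold higher number from compound 1 to compound 3 (0.29 log units; within the scatter), so in this pair the two ring substituents cannot be told apart in this assay.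

The step to compound 3 joins two edits, the loss of the methyl on the amine nitrogen and the gain of the chlorine on the ring, and the compounds shown do not separate them. From the compounds shown here alone, what stays open is how a plain benzylamino group or a (4-chlorobenzyl)(methyl)amino group would read, and whether a methoxy group on the ring or a longer chain would keep this level of inhibition.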